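Iodo for trifluoromethyl at the aryl substituent

The source may report more compounds than this note shows. Statements on the series, on what has been measured and on what is new or still open speak of the compounds shown alone.

Measured compounds:
compound 1 `Cc1ccccc1-n1nc(C)c2c1NC(=O)[C@H](C)S[C@@H]2c1ccc(Oc2ccccc2)cc1` — 118%
compound 2 `Cc1nn(-c2ccccc2C(C)C)c2c1[C@@H](c1ccc(Oc3ccccc3)cc1)S[C@@H](C)C(=O)N2` — 174%
compound 3 `Cc1nn(-c2ccccc2C(F)(F)F)c2c1C(c1ccc(Oc3ccccc3)cc1)SC(C)C(=O)N2` — 50%

In an assay on isolated protein for agonist activity at Bile acid receptor (Homo sapiens), read by AlphaScreen, with a stated time of 30 min (on this read-out lower numbers stand for smaller maximal responses and higher numbers for larger maximal responses), compound 3 gives 50%, the lowest of the three numbers: compound 1 lies above it beyond the scatter, and compound 2 lies further above still. Among the measured compounds shown here, the only step between measured compounds that differ in one place, a number 56 percentage points higher from compound 1 to compound 2 (beyond the scatter), concerns an isopropyl in place of a methyl on an aromatic carbon, and it is large. For the measured compounds named here, it shows that the group on that aromatic carbon matters for this assay, but it does not involve a trifluoromethyl or an iodo, so no measured step bears directly on the change to compound 4 `Cc1nn(-c2ccccc2I)c2c1C(c1ccc(Oc3ccccc3)cc1)SC(C)C(=O)N2`.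

That change is iodo in place of trifluoromethyl on an aromatic carbon. Going by the values given here, with no directly comparable step, the size and direction of the step in this assay cannot be read from the data; a moderate rise from the low value of compound 3 is expected rather than a large one, with a wide range. The expected step is a number 25 percentage points higher from compound 3 to compound 4 (beyond the scatter). Compound 4 is estimated at 75%, within 35% to 140%.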

Compound 4, largest response reached (reported as efficacy), in percent of the reference or control that the assay uses: 130%
The estimate for compound 4 lay 55 percentage points below the measured number; the range from low to high includes it.
By their numbers in this assay, from the lowest: compound 3; then compound 1; then compound 4; then compound 2.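

In this assay iodo in place of trifluoromethyl gives a number 80 percentage points higher from compound 3 to compound 4 (beyond the scatter) and this large step shows that a single group on this aromatic carbon, ortho to a large group, can decide much of the maximal response. Among the compounds shown here, until now the only step with a single difference was one from methyl to isopropyl, so this result adds a second, quite different pair of groups whose exchange also moves the number beyond the scatter. Nothing given here explains the step.

The compounds shown leave open how chloro, bromo, methoxy or an amine would read out on the same aromatic carbon. They also leave open whether the exchange of trifluoromethyl for iodo would give a step of similar size on a core carrying other groups.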